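The source may hold more compounds than are shown below. What is called first, only, known or untested is meant among the compounds shown, and "the series" means these compounds.

Measured compounds:
compound 1, `Cc1ccc(CSc2nc(C3CCCCC3)c(C#N)c(=O)[nH]2)cc1`: 38700 nM
compound 2, `Cc1ccc(C)c(CSc2nc(C3CCN(C)CC3)c(C#N)c(=O)[nH]2)c1`: 127000 nM

Two compounds were measured in an assay on isolated protein for inhibition of Rap guanine nucleotide exchange factor 4 (Homo sapiens), read by fluorescence and cAMP accumulation; a lower number here means a stronger inhibitor, a higher number a weaker inhibitor. Compound 1 `Cc1ccc(CSc2nc(C3CCCCC3)c(C#N)c(=O)[nH]2)cc1` gives 38700 nM. Compound 2 `Cc1ccc(C)c(CSc2nc(C3CCN(C)CC3)c(C#N)c(=O)[nH]2)c1` gives 127000 nM. Of these two numbers, compound 1 holds the lower one, and its gap to compound 2 lies beyond the usual scatter of repeated measurements. Neither compound is a strong inhibitor, however, as both values sit far up the concentration scale.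

Compound 3 `N#Cc1c(C2CCCCC2)nc(SCC(=O)O)[nH]c1=O` has not yet been measured. It differs from compound 1 in one place: carboxy in place of 4-methylphenyl on a saturated chain carbon bound to a sulfur. The replacement takes away the ring of the thioether side chain and leaves a short carboxy chain in its place. Among the compounds with values here, no step between measured compounds tells how such a change plays out on this core, so the expectation rests on the weak starting point of compound 1 alone. A rise in the number is expected a 2.3-fold higher number from compound 1 to compound 3 (0.37 log units; beyond the scatter), a step beyond the scatter, toward weaker inhibition. For compound 3 the estimated value is 90000 nM, with a range from 20000 nM to 400000 nM. The assay may well report only a limit for compound 3 rather than a number.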

Compound 3, half-maximal inhibitory concentration: > 300000 nM
Compound 3: a limit, no number (the forecaster's own chance of this, stated with the estimate: 40%); middle value at least 3.3-fold (0.52 log units) away from the limit.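

In this assay compound 3 gives > 300000 nM, which is a limit of the assay and not a number. Within the data shown here, exchanging 4-methylbenzyl for carboxymethyl brings an at least 7.7-fold higher number from compound 1 to compound 3 (0.88 log units; beyond the scatter), the first evidence that the group on this saturated chain carbon bound to a sulfur affects inhibition, with the cyclohexyl-bearing core of compound 1 otherwise unchanged. The step has a lower bound only, so the real size of the loss at this place cannot be read, and the assay offers little room above the weak value of compound 1: the limit of > 300000 nM in this assay, at which 1 of the 3 values shown sits.

The change removes the aromatic ring and brings in the carboxy group in a single move, and the compounds shown cannot separate the two, so it remains open which of them accounts for the weaker inhibition. Also open, as far as these compounds go, is how the assay would read a benzyl group carrying a carboxylic acid on its ring, a simple methyl ester of the carboxy chain, or an amine or a longer alkyl chain at this place.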